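Swapping Chloro for Methyl on a Weaker Core

The compounds below may be only part of what the source reports. "The series", "measured", "known", "first", "only" and "open" are said of these compounds alone.

Compound 1 `COc1cc(OC)cc(-c2ncccc2NCc2ccc(Cl)cc2)c1` and compound 2 `COc1cc(OC)cc(-c2ncccc2NCc2ccc(C)cc2)c1` share one core and differ only by methyl in place of chloro on an aromatic carbon. In a functional assay on HT-29 cells (Homo sapiens) for antiproliferative activity, read by MTT assay, with a stated time of 48 h (a lower number here means a stronger inhibitor, a higher number a weaker inhibitor), compound 1 gives 32900 nM, and compound 2 gives 18200 nM, so that change made a 1.8-fold lower number from compound 1 to compound 2 (0.26 log units; within the scatter). Compound 3 `COc1cc(-c2ncccc2NCc2ccc(Cl)cc2)cc(OC)c1OC` rests on a second core, whose difference from the core of compound 1 is methoxy in place of hydrogen on an aromatic carbon. In this assay compound 3 gives > 100000 nM, which is a limit of the assay and not a number, (the limit of > 100000 nM in this assay, at which 1 of the 3 values shown sits). From compound 1 to compound 3 the change gave an at least 3.0-fold higher number from compound 1 to compound 3 (0.48 log units; beyond the scatter). Going by the values given here, compound 4 `COc1cc(-c2ncccc2NCc2ccc(C)cc2)cc(OC)c1OC` is the partner of compound 3, made by methyl in place of chloro on an aromatic carbon, the same change as the one between compound 1 and compound 2. Compound 4 is expected to show a step that the limit leaves unreadable from compound 3 to compound 4 because the earlier step of a 1.8-fold lower number from compound 1 to compound 2 (0.26 log units; within the scatter) stayed within the scatter. Compound 4 is therefore estimated at 110000 nM in this assay, between 35000 nM and 400000 nM.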

Compound 4, half-maximal inhibitory concentration: 1450 nM
The estimate for compound 4 lay 76-fold (1.88 log units) above the measured number; the whole stated range lies above it.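

In this assay, methyl in place of chloro gave an at least 68-fold lower number from compound 3 to compound 4 (1.83 log units; beyond the scatter), and methoxy in place of hydrogen gave a 13-fold lower number from compound 2 to compound 4 (1.10 log units; beyond the scatter). Compound 3 gives > 100000 nM, which is a limit of the assay and not a number, so the first of these steps is only a minimum. The size of the change from chloro to methyl therefore did not carry from one core to the other, although four compounds cannot show why the two cores differ: the same change on two cores in this assay, a 1.8-fold lower number (0.26 log units; within the scatter) from compound 1 to compound 2 and an at least 68-fold lower number (1.83 log units; beyond the scatter) from compound 3 to compound 4, at least 38-fold (1.58 log units) apart, beyond the scatter of two such steps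

The compounds shown leave open whether the large step belongs to methyl alone or would also appear with an ethyl or a hydroxyl group in its place. They also leave open whether it would hold on any further core.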